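Shortening the hydroxyalkyl chain on a spiro amide series

A few compounds are considered here, and "the series" means these few. Any claim that something is new, unique, unknown or untested is made for them only; others in the source may bear on it.

Of the compounds shown here, two of one series have been measured in an assay on HEK293 cells for displacement of a labelled ligand from NPC1-like intracellular cholesterol transporter 1 (Homo sapiens); on this read-out higher numbers stand for weaker inhibition and lower numbers for stronger inhibition. Compound 1 has the structure `O=C(CN1CN(c2ccccc2)C2(CCN(C(=O)c3ccc(C4CCCCC4)cc3)CC2)C1=O)NCCCCO`, and in this assay compound 1 gives 10300 nM. Compound 2, with the structure `CC(C)(C)OC(=O)NCCCCCNC(=O)CN1CN(c2ccccc2)C2(CCN(C(=O)c3ccc(C(C)(C)C)cc3)CC2)C1=O`, gives 13700 nM in this assay. These two numbers lie within the usual scatter of each other, so compound 1 stands side by side with compound 2 and neither can be told apart from the other on these data.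

Compound 3, with the structure `O=C(CN1CN(c2ccccc2)C2(CCN(C(=O)c3ccc(C4CCCCC4)cc3)CC2)C1=O)NCCO`, is not yet measured. It differs from compound 1 in a single place: hydroxy in place of 2-hydroxyethyl on a saturated chain carbon, two bonds along the chain from an amide-type nitrogen. Within the data shown here, no measured pair in this set shows the effect of such a change, so there is nothing here to say which way the number should move.

On that basis the step from compound 1 to compound 3 is expected to be a 1.2-fold higher number from compound 1 to compound 3 (0.07 log units; within the scatter), that is, no change beyond the scatter. Compound 3 is therefore estimated to give about 12000 nM in this assay, in a range from 5000 nM to 30000 nM.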

Compound 3, half-maximal inhibitory concentration: 2000 nM
Compound 3: the middle estimate sits 6.0-fold (0.78 log units) above what was measured, and the stated range ends above it.
By their numbers in this assay, from the lowest: compound 3; then compounds 1 and 2 (each within the scatter of the next).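

Among these compounds, this position turns out to respond to chain length, which the earlier compounds could not show because they differ in more than one place. In this assay, cutting the 4-hydroxybutyl group back to 2-hydroxyethyl, two bonds along the chain from an amide-type nitrogen, gives a 5.2-fold lower number from compound 1 to compound 3 (0.71 log units; beyond the scatter) and so lies beyond the scatter, with the rest of the molecule unchanged. The hydroxy at the chain end is present in both compounds, so this step reflects a change in the length of the chain and not the loss of that hydroxy, though no measurement shown here explains why the shorter chain gives the lower number.

Among the compounds shown here, with only two chain lengths on this core, it remains open whether the number would keep falling with a hydroxymethyl group, or where a 3-hydroxypropyl group would fall. Also open, on these data alone, is whether the hydroxy itself matters at all, a question that a plain ethyl chain, or an amine or a carboxylic acid in its place at the chain end, would help to answer.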